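A few compounds are considered here, and "the series" means these few. Any claim that something is new, unique, unknown or untested is made for them only; others in the source may bear on it.

Compound 2 `CCOC(=O)c1cnc(N2CCN(Cc3ccccc3C(=O)OC)CC2)nc1Oc1c(C)cc(-c2ccc(C#N)cc2)cc1C` is tested in an ADME assay on MT4 cells (Homo sapiens) for cytotoxicity, read by MTT assay, with a stated time of 4 days; on this read-out higher numbers stand for lower toxicity in this test and lower numbers for higher toxicity in this test. In this assay compound 2 gives > 125000 nM, which is a limit of the assay rather than a number. Compound 1 `CCOC(=O)c1cnc(N2CCN(Cc3cccc(C#N)c3)CC2)nc1Oc1c(C)cc(-c2ccc(C#N)cc2)cc1C` gives > 125000 nM in this assay, likewise a limit. The step that the two limits leave unreadable from compound 1 to compound 2 therefore cannot be read, since both values sit on (the limit of > 125000 nM in this assay, at which 2 of the 2 values shown sit). Compound 3 `CCOC(=O)c1cnc(N2CCN(Cc3ccc(C(N)=O)cc3)CC2)nc1Oc1c(C)cc(-c2ccc(C#N)cc2)cc1C` differs from compound 2 by 4-carbamoylphenyl in place of 2-(methoxycarbonyl)phenyl on a saturated chain carbon bound to an amine nitrogen in a ring. No readable measured step bears on this change, so the expected step in this assay is a number no higher from compound 2 to compound 3 (the limit leaves the size open). Compound 3 is thus expected to give about 125000 nM in this assay, within 60000 nM to 250000 nM.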

Compound 3, half-maximal cytotoxic concentration: 66500 nM
For compound 3 the middle estimate is 1.9-fold (0.27 log units) above the measured one, and the stated range covers the measured number.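

In this assay, for the compounds shown here, compound 3 gives the first value at this position, on a saturated chain carbon bound to an amine nitrogen in a ring, that is a number and not a limit. This allows two steps to be read as floors: an at least 1.8-fold lower number from compound 2 to compound 3 (0.27 log units; that floor lies within the scatter), and an at least 1.8-fold lower number from compound 1 to compound 3 (0.27 log units; that floor lies within the scatter). Neither floor alone shows a real difference, and the full sizes stay open because the other two values are limits: the limit of > 125000 nM in this assay, at which 2 of the 3 values shown sit.

As far as these compounds go, it remains open what a carboxylic acid or an amine on this phenyl ring would give. Also open, from the compounds shown here alone, is whether the carbamoyl group or its place on the ring sets the number.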